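Cyano for fluoro on the 4-substituted benzoyl group

A few compounds are considered here, and "the series" means these few. Any claim that something is new, unique, unknown or untested is made for them only; others in the source may bear on it.

In a functional assay on HepG2 cells (Homo sapiens) for inhibition, read by MTT assay, with a stated time of 24 h (a lower number here means a stronger inhibitor, a higher number a weaker inhibitor), compound 1 (`CCN(CC)c1ccc(/C=N/NC(=O)CNC(=O)c2ccc(C#N)cc2)c(OCc2ccccc2Cl)c1`) reaches only a limit (> 50000 nM). Among the measured compounds shown here, compound 2 (`O=C(CNC(=O)c1ccc(F)cc1)N/N=C/c1ccccc1OCc1ccccc1Cl`) carries the only actual number so far (24900 nM) in this assay and is the reference here. Compound 3 (`N#Cc1ccc(C(=O)NCC(=O)N/N=C/c2ccccc2OCc2ccccc2Cl)cc1`) has cyano in place of fluoro on an aromatic carbon, para to a large group (cyano in place of fluoro on an aromatic carbon). For the measured compounds named here, no measured step isolates this change. The expected step of a 1.2-fold higher number from compound 2 to compound 3 (0.08 log units; within the scatter) in this assay is small, leaning toward weaker inhibition but staying within the scatter. Compound 3 is estimated at 30000 nM with an expected range of 13000 nM to 50000 nM in this assay as the working figure.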

Compound 3, half-maximal inhibitory concentration: > 50000 nM
Compound 3 ended at the assay's limit (the forecaster's own chance of this, stated with the estimate: 30%); middle value at least 1.6-fold (0.22 log units) from the limit.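

In this assay, cyano in place of fluoro now has a measured step at this position: an at least 2.0-fold higher number from compound 2 to compound 3 (0.30 log units; that floor lies within the scatter). Compound 3 reaches only a limit, so the step gives a floor and no upper size, and the series offers little room to resolve weaker compounds because of that limit: the limit of > 50000 nM in this assay, at which 2 of the 3 values shown sit. The step between compound 1 and compound 3 cannot be read, as both values are limits.

Still open, going by these compounds, is whether any group in place of the fluoro, such as an amine or a methoxy group, gives a lower number than compound 2. The effect of diethylamino on the shared core also remains unresolved.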